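The compounds below may be only part of what the source reports. "The series", "measured", "known", "first", "only" and "open" are said of these compounds alone.

Measured so far in an assay on isolated protein for inhibition of DNA topoisomerase 1 (Homo sapiens); on this read-out higher numbers stand for weaker inhibition and lower numbers for stronger inhibition:
compound 1 `COc1cc(C(C)O)c(OC)c2c1C(=O)C=CC2=O`: 111000 nM
compound 2 `CCC(O)c1cc(OC)c2c(c1OC)C(=O)C=CC2=O`: 122000 nM

Compound 2 gives the higher of the two numbers, though its gap to compound 1 stays within the scatter, at a 1.1-fold higher number from compound 1 to compound 2 (0.04 log units; within the scatter). Compound 3 `CCCCCCCC(O)c1cc(OC)c2c(c1OC)C(=O)C=CC2=O` differs from compound 2 by pentyl in place of hydrogen on a saturated chain carbon, three bonds along the chain from an aromatic carbon and an oxygen on a saturated carbon. Among the compounds with values here, the only measured step at this part of the shared core, from compound 1 to compound 2, was within the scatter, so no shift beyond the scatter is expected in this assay for compound 3; the expected step is a 1.0-fold lower number from compound 2 to compound 3 (0.01 log units; within the scatter). Compound 3 is therefore estimated at 120000 nM, in a range from 50000 nM to 300000 nM.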

Compound 3, half-maximal inhibitory concentration: 43900 nM
Estimate against measurement, compound 3: 2.7-fold (0.44 log units) above; the whole stated range lies above it.
By their numbers in this assay, from the lowest: compound 3; then compounds 1 and 2 (each within the scatter of the next).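

In this assay this position does respond to its chain, which the small methyl step could not show: pentyl in place of hydrogen gives a 2.8-fold lower number from compound 2 to compound 3 (0.44 log units; beyond the scatter) and hexyl in place of hydrogen gives a 2.5-fold lower number from compound 1 to compound 3 (0.40 log units; beyond the scatter) in the same direction. The longest chain shown therefore goes with stronger inhibition, though the shift is modest. No measurement here explains this shift. Still open, going by these compounds, is whether a longer chain would lower the number further, and whether an amine or a carboxylic acid at the end of the chain would keep the gain.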